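This account rests on a few compounds, and the source may have more. Where it says the series, first, only, none or still open, it means among the compounds named here.

Measured so far:
compound 1, `CC(=O)N1CCN(S(=O)(=O)c2ccc(F)cc2)C(C)C1`: 0.1 mg/kg
compound 2, `CC(=O)N1CCN(S(=O)(=O)c2ccc(F)cc2)CC1c1ccccc1`: > 10 mg/kg
compound 3, `CCC(=O)N1CCNC(c2ccccc2)C1`: > 10 mg/kg

In a functional assay on the whole organism with Mus musculus as the target, with stated times of 24 h and 20 min (on this read-out higher numbers stand for an effect only at larger amounts of compound and lower numbers for an effect already at smaller amounts), compound 1 gives 0.1 mg/kg. Compound 2 reaches only a limit of the assay, > 10 mg/kg. Compound 3 also reaches only a limit, > 10 mg/kg. Compound 3 thus stands where most of the values sit, (the limit of > 10 mg/kg in this assay, at which 2 of the 3 values shown sit), so no number is known for it. Compound 4, `CC(=O)N1CCNC(c2ccccc2)C1`, is still to be measured. It differs from compound 3 in one place: hydrogen in place of methyl on a saturated chain carbon bound to a carbonyl carbon, that is propanoyl to acetyl. Going by the values given here, no measured pair shows this change on its own, so its size cannot be read from these numbers. Compound 4 is expected to stay near the same limit, with an expected step of a number no higher from compound 3 to compound 4 (the limit leaves the size open) that is none beyond the scatter. The estimate for compound 4 is 10 mg/kg, between 3 mg/kg and 30 mg/kg.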

Compound 4, minimum effective dose: > 10 mg/kg
Compound 4: a limit, no number (the forecaster's own chance of this, stated with the estimate: 70%); the middle value sits exactly at the limit.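

Going by these compounds alone, compound 3 and compound 4 both end at a limit of the assay rather than a number, so no step between them can be read. The compounds shown leave open whether changing propanoyl to acetyl affects the minimum effective dose at all.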